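Swapping a chain for a ring on one oxygen

The compounds below may be only part of what the source reports. "The series", "measured", "known", "first", "only" and "open" are said of these compounds alone.

- Compound 1 `COc1ncc(-c2cc(OC(C)C)c3nc(N)nc(C)c3c2)cc1NS(=O)(=O)c1ccc(F)cc1F` gives 140 nM
- Compound 2 `COCCOc1cc(-c2cnc(OC)c(NS(=O)(=O)c3ccc(F)cc3F)c2)cc2c(C)nc(N)nc12` gives 200 nM

Going by the values given here, both numbers come from a functional assay on NCI-H460 cells (Homo sapiens) for cytotoxicity, read by MTT assay, with a stated time of 96 h (a higher number here means a weaker inhibitor, a lower number a stronger inhibitor), and lie within the scatter of each other, so compound 2 stands level with compound 1, the only other measured compound. Compound 3 `COc1ncc(-c2cc(OC3CCCCC3)c3nc(N)nc(C)c3c2)cc1NS(=O)(=O)c1ccc(F)cc1F` has not yet been measured. It carries cyclohexyl in place of 2-methoxyethyl on an oxygen on an aromatic ring. Among the compounds with values here, the one measured step on that oxygen, 2-methoxyethyl in place of isopropyl, is a 1.4-fold higher number from compound 1 to compound 2 (0.15 log units; within the scatter) and is small. Within the data shown here, it is only one step, though, and neither compound 1 nor compound 2 has a ring on that oxygen, so the range must stay wide. The estimate means a 1.2-fold lower number from compound 2 to compound 3 (0.07 log units; within the scatter) and so no change beyond the scatter is expected. In this assay the expected value for compound 3 is 170 nM (range 70 nM to 420 nM).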

Compound 3, half-maximal inhibitory concentration: 96 nM
Estimate against measurement, compound 3: 1.8-fold (0.25 log units) above, and the stated range covers the measured number.
By their numbers in this assay, from the lowest: compounds 3, 1 and 2 (each within the scatter of the next, the first and the last beyond it).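

In this assay, going by these compounds alone, putting a ring on this oxygen gives the first step at this position that clears the scatter (a 2.1-fold lower number from compound 2 to compound 3 (0.32 log units; beyond the scatter)), although the step is modest. Measured against isopropyl, the same ring leaves the number level (a 1.5-fold lower number from compound 1 to compound 3 (0.16 log units; within the scatter)), so having a ring does not by itself set these compounds apart: only the 2-methoxyethyl and cyclohexyl compounds are separated. Nothing available here explains the step from 2-methoxyethyl to cyclohexyl.

A plain carbon chain such as n-butyl on the same oxygen could show whether that step follows the ring that enters or the chain oxygen that leaves. As far as these compounds go, it also remains open how a phenyl ring, or a chain ending in an amine or a carboxylic acid, would behave here.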